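The compounds below may be only part of what the source reports. "The series", "measured", "known", "first", "only" and "open" are said of these compounds alone.

Compound 1 `C[C@@H]1CN(C(=O)c2nc(Nc3cc(C4CC4)[nH]n3)c3cc(Cl)ccc3n2)CCN1C(=O)OC(C)(C)C` — in an ADME assay on S9 fraction from liver (Rattus norvegicus), read by LC-MS, with a stated time of 60 min, at 37 degrees C (a higher number here means that more of the compound is left, a lower number that less of the compound is left), compound 1 gives 71.3%.
Compound 2 `CC(OC(=O)N1CCN(C(=O)c2nc(Nc3cc(C4CC4)[nH]n3)c3cc(Cl)ccc3n2)C[C@H]1C)OC(=O)C(C)(C)C` — in this assay compound 2 gives 66.3%.

Going by the values given here, of the two numbers measured so far, compound 2 has the lower one, and its nearest neighbour is compound 1, whose number lies higher by a margin that stays within the scatter. Among the compounds with values here, the one measured step, a number 5 percentage points lower from compound 1 to compound 2 (within the scatter), is therefore no more than noise on this read-out.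

Compound 3 `CCOC(=O)N1CCN(C(=O)c2nc(Nc3cc(C4CC4)[nH]n3)c3cc(Cl)ccc3n2)C[C@H]1C` has not yet been measured in this assay. It differs from compound 2 in a single place: hydrogen in place of ((tert-butyl)carbonyl)oxy on a saturated chain carbon bound to an oxygen next to a carbonyl group and a saturated chain carbon. Within the data shown here, the only step that bears on this change is the one from compound 1 to compound 2, which was small; on that basis no step beyond the scatter is expected for compound 3, with a slight lean upward. Compound 3 is expected to give 72% in this assay, within a range of 56% to 88%. That estimate means a step of a number 5.7 percentage points higher from compound 2 to compound 3 (within the scatter) is expected.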

Compound 3, percent of the compound remaining: 48.5%
Compound 3: middle estimate off by 23.5 percentage points, on the high side; the measured number lies below the stated range.
By their numbers in this assay, from the lowest: compound 3; then compounds 2 and 1 (each within the scatter of the next).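

Going by these compounds alone, the group on an oxygen next to a carbonyl group does matter in this assay, which the earlier compounds did not reveal: ethyl in place of tert-butyl gives a clear change (a number 22.8 percentage points lower from compound 1 to compound 3 (beyond the scatter)), and hydrogen in place of ((tert-butyl)carbonyl)oxy on the saturated chain carbon gives another (a number 17.8 percentage points lower from compound 2 to compound 3 (beyond the scatter)). The earlier exchange of tert-butyl for 1-(((tert-butyl)carbonyl)oxy)ethyl had stayed within the scatter (a number 5 percentage points lower from compound 1 to compound 2 (within the scatter)), so compound 1 and compound 2 stand together, with compound 3 apart from both. Nothing at hand explains why ethyl stands apart from these two larger groups.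

The compounds shown leave open how the number runs from ethyl to tert-butyl, which isopropyl or a longer chain on that oxygen would help to trace. Also open, from the compounds shown here alone, is whether a group carrying an amine or a carboxylic acid there would fall with ethyl or stand with tert-butyl.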